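Aryl replacement on the shared core and antiproliferative potency

The compounds below may be only part of what the source reports. "The series", "measured", "known", "first", "only" and "open" are said of these compounds alone.

compound 1, `COc1cc(-n2cnc3ccc(-c4ccccc4Cl)cc32)cc(OC)c1OC`: > 10000 nM
compound 2, `COc1cc(-n2cnc3ccc(-c4ccc(C(C)=O)cc4)cc32)cc(OC)c1OC`: 450 nM
compound 3, `COc1ccc(-c2ccc3ncn(-c4cc(OC)c(OC)c(OC)c4)c3c2)cc1`: 82 nM

In a functional assay on SGC-7901 cells (Homo sapiens) for antiproliferative activity, read by MTT assay, with a stated time of 72 h (a higher number here means a weaker inhibitor, a lower number a stronger inhibitor), compound 1 gives > 10000 nM, which is a limit of the assay and not a number. Going by the values given here, it is the one value here that sits at the limit of > 10000 nM in this assay, at which 1 of the 3 values shown sits, so compound 1 stands as the weakest of the three measured compounds. Compound 4, `COc1cc(-n2cnc3ccc(-c4ccc(O)cc4)cc32)cc(OC)c1OC`, is not yet measured in this assay. (4-hydroxyphenyl in place of 2-chlorophenyl on an aromatic carbon). Two measured steps start from compound 1 and bear on this change: an at least 22-fold lower number from compound 1 to compound 2 (1.34 log units; beyond the scatter) and an at least 120-fold lower number from compound 1 to compound 3 (2.08 log units; beyond the scatter); the further step a 5.5-fold lower number from compound 2 to compound 3 (0.74 log units; beyond the scatter) shows that the oxygen-bearing group gave the stronger result. A similarly large drop in this assay is therefore expected for compound 4, about an at least 66-fold lower number from compound 1 to compound 4 (1.82 log units; beyond the scatter). Compound 4 is estimated at 150 nM, in the range 40 nM to 600 nM.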

Compound 4, half-maximal inhibitory concentration: > 10000 nM
Compound 4: only a limit was reported; the forecaster's own chance of this, stated with the estimate: 5%; middle value at least 66-fold (1.82 log units) away from the limit.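

In this assay compound 4 gives > 10000 nM, a limit of the assay and not a number, and the same limit applies to compound 1: the limit of > 10000 nM in this assay, at which 2 of the 4 values shown sit.

An oxygen on the phenyl ring is therefore not enough for activity at this position: loss of the methyl alone gives an at least 120-fold higher number from compound 3 to compound 4 (2.08 log units; beyond the scatter), and the hydroxy group also falls behind the acetyl group, with an at least 22-fold higher number from compound 2 to compound 4 (1.34 log units; beyond the scatter). The step from compound 1 to compound 4 cannot be read, as both values are limits.

Still open, as far as these compounds go, is whether the activity of compound 3 needs the methyl specifically, or would persist with a longer chain such as ethoxy or with an amine in the same place.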